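The compounds below may be only part of what the source reports. "The series", "measured", "known", "first", "only" and "open" are said of these compounds alone.

Measured in a functional assay (plasma) for inhibition, with Homo sapiens as the target; on this read-out lower numbers stand for stronger inhibition and higher numbers for weaker inhibition:
- Compound 1 `O=C(O)CCC/C=C\C[C@H]1/C(=N/OC(c2ccccc2)c2ccccc2)CC[C@@H]1NS(=O)(=O)c1ccc(Cl)cc1`: 17000 nM
- Compound 2 `Cc1ccc(S(=O)(=O)N[C@H]2CC[C@H](O)[C@@H]2C/C=C\CCC(=O)O)cc1`: 2500 nM
- Compound 3 `O=C(O)CCC/C=C\C[C@H]1/C(=N/OC(c2ccccc2)c2ccccc2)CC[C@@H]1NS(=O)(=O)c1ccc(F)cc1`: 17000 nM

Compound 3, at 17000 nM, stands level with compound 1, and together they hold the highest of the three numbers. Compound 4 `Cc1ccc(S(=O)(=O)N[C@H]2CC/C(=N\OC(c3ccccc3)c3ccccc3)[C@@H]2C/C=C\CCCC(=O)O)cc1` carries methyl in place of fluoro on an aromatic carbon, para to a large group: methyl in place of fluoro on an aromatic carbon. Among the measured compounds shown here, the only measured step of this kind is no change at the digits printed from compound 1 to compound 3 (within the scatter), with fluoro in place of chloro on an aromatic carbon. Compound 2 also bears the (4-methylphenyl)sulfonyl group but differs elsewhere as well, so it offers no clean comparison. No step beyond the scatter is therefore expected in this assay. The expected step is no change at the digits printed from compound 3 to compound 4 (within the scatter). For compound 4 the estimated value is 17000 nM, with an expected range of 8000 nM to 35000 nM.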

Compound 4, half-maximal inhibitory concentration: 5600 nM
Compound 4: the middle estimate sits 3.0-fold (0.48 log units) above what was measured, and the stated range ends above it.
By their numbers in this assay, from the lowest: compound 2; then compound 4; then compounds 1 and 3 (each within the scatter of the next).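

In this assay, the place on the aromatic ring para to a large group turns out to respond to what it carries: methyl gives a 3.0-fold lower number from compound 3 to compound 4 (0.48 log units; beyond the scatter) and a 3.0-fold lower number from compound 1 to compound 4 (0.48 log units; beyond the scatter), while the swap between the two halogens gave no change at the digits printed from compound 1 to compound 3 (within the scatter). Methyl is thus the one group of the three set apart at this place, and no measurement here accounts for the difference. On these data alone, whether an ethyl, a methoxy or an amine at the same place would go further in this direction stays open, as does whether the step holds on a core other than that of compound 1.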